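The source may report more compounds than this note shows. Statements on the series, on what has been measured and on what is new or still open speak of the compounds shown alone.

Measured so far in a physicochemical assay for solubility, read by HPLC, with a stated time of 24 h, at pH 7; on this read-out higher numbers stand for higher solubility and lower numbers for lower solubility:
compound 1 (`OC[C@@H](O[C@H]1CCCN(Cc2ncc[nH]2)[C@H]1c1ccccc1)c1cc(Cl)cc(Cl)c1`): 60000 nM
compound 2 (`O=C(O)c1ccc(CN2CCC[C@H](O[C@H](CO)c3cc(Cl)cc(Cl)c3)[C@@H]2c2ccccc2)cc1`): 85000 nM
compound 3 (`OC[C@@H](O[C@H]1CCCN(Cc2cccc3nonc23)[C@H]1c1ccccc1)c1cc(Cl)cc(Cl)c1`): 154000 nM

Compound 1 is set apart only by a 2.6-fold higher number from compound 1 to compound 3 (0.41 log units; beyond the scatter), while a 1.4-fold higher number from compound 1 to compound 2 (0.15 log units; within the scatter) and a 1.8-fold higher number from compound 2 to compound 3 (0.26 log units; within the scatter) stay close. The next compound, compound 4 (`Clc1cc(Cl)cc(CO[C@H]2CCCN(Cc3ncc[nH]3)[C@H]2c2ccccc2)c1`), keeps the rest of compound 1 and changes one place: hydrogen in place of hydroxymethyl on a saturated chain carbon bound to an aromatic carbon and an oxygen on a saturated carbon. All measured steps lie on the saturated chain carbon bound to an amine nitrogen in a ring, so none bears directly on this change and they offer only a rough scale. In this assay a modest move to a lower number is expected, an estimated 2.1-fold lower number from compound 1 to compound 4 (0.33 log units; beyond the scatter) on uncertain grounds. Compound 4 is expected near 28000 nM with an estimated range of 8000 nM to 90000 nM overall.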

Compound 4, solubility: 120000 nM
For compound 4 the middle estimate is 4.3-fold (0.63 log units) below the measured one; the whole stated range lies below it.
By their numbers in this assay, from the lowest: compounds 1, 2, 4 and 3 (each within the scatter of the next, the first and the last beyond it).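

This is the first step shown at this place, on a saturated chain carbon bound to an aromatic carbon and an oxygen on a saturated carbon. In this assay, hydrogen in place of hydroxymethyl gives a 2.0-fold higher number from compound 1 to compound 4 (0.30 log units; within the scatter), so this one exchange does not separate the two compounds on this read-out. Nothing shown explains this result.

Going by these compounds, only hydroxymethyl and hydrogen have been compared at this place, so it remains open whether an aminomethyl group or a longer chain there would give a step beyond the scatter. On these data alone, it is also open whether the same exchange would read alike with a different group on the saturated chain carbon bound to the ring amine nitrogen.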